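Compound 3 and Substitution on Its Ring Amine Nitrogen

The source may hold more compounds than are shown below. What is called first, only, known or untested is meant among the compounds shown, and "the series" means these compounds.

Values in a functional assay on HepG2 cells (Homo sapiens) for cytotoxicity, read by MTT assay, with a stated time of 72 h; on this read-out higher numbers stand for weaker inhibition and lower numbers for stronger inhibition:
- Compound 1 `CNC(=O)c1cc(Oc2ccc(C3=NNC(c4ccc([N+](=O)[O-])cc4)C3)cc2)ccn1`: > 50000 nM, a limit of the assay.
- Compound 2 `CNC(=O)c1cc(Oc2ccc(C3=NNC(c4ccc(Br)cc4)C3)cc2)ccn1`: 57600 nM.
- Compound 3 `CNC(=O)c1cc(Oc2ccc(C3=NNC(c4cccc(Cl)c4Cl)C3)cc2)ccn1`: 4990 nM.

Compound 3 has the lower of the two actual numbers, and compound 2 is its nearest neighbour. The change to compound 4 `CNC(=O)c1cc(Oc2ccc(C3=NN(C(N)=S)C(c4cccc(Cl)c4Cl)C3)cc2)ccn1` is a group of 3 heavy atoms (1 carbon, 1 nitrogen, 1 sulfur; no ring) in place of a hydrogen atom, on an amine nitrogen in a ring.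

The measured steps all exchange the aryl group on a saturated ring carbon. They are a 12-fold lower number from compound 2 to compound 3 (1.06 log units; beyond the scatter), an at least 10-fold lower number from compound 1 to compound 3 (1.00 log units; beyond the scatter) and a step that the limit leaves unreadable from compound 1 to compound 2. None of them alters the amine nitrogen, so they bear on this change only indirectly, as a guide to how far numbers can move among these compounds. Among the measured compounds shown here, with no direct precedent, no step beyond the scatter is expected in this assay, and no direction is favoured with confidence. The reference point is compound 3 at 4990 nM. The expected step is a 1.7-fold lower number from compound 3 to compound 4 (0.22 log units; within the scatter). For compound 4 the estimated value is 3000 nM, with an expected range of 700 nM to 15000 nM.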

Compound 4, half-maximal inhibitory concentration: 1890 nM
Beside the measured number, compound 4's estimate is 1.6-fold (0.20 log units) above it; the measured number falls inside the stated range.
By their numbers in this assay, from the lowest: compound 4; then compound 3; then compound 2.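

In this assay, a group of 3 heavy atoms (1 carbon, 1 nitrogen, 1 sulfur; no ring) in place of a hydrogen atom on the amine nitrogen in the ring gives a 2.6-fold lower number from compound 3 to compound 4 (0.42 log units; beyond the scatter). This is the first step shown at this nitrogen, so the number also moves beyond the scatter with a change away from the aryl group on the saturated ring carbon, and the new group is compatible with the 2,3-dichlorophenyl group two atoms of the series already carry in compounds 3 and 4. Nothing at hand accounts for the size or direction of this step.

From the compounds shown here alone, whether an acetyl group, a methyl group or the oxygen counterpart of the new group would move the number in the same way remains open. Also open, going by these compounds, is whether the same change on compound 2 or another aryl variant would give a similar step.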